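Carboxy to methyl on the shared core of compound 1

A few compounds are considered here, and "the series" means these few. Any claim that something is new, unique, unknown or untested is made for them only; others in the source may bear on it.

Compound 1, `Cc1cc(C(=O)O)nn1-c1ccc(S(=O)(=O)NC(=S)NCc2ccccc2)cc1`, in a functional assay on the whole organism (blood, strain albino) with Mus musculus as the target, with stated times of 6 days and 4 h, at a dose of 0.4 mmol/kg by the oral route (on this read-out higher numbers stand for more inhibition at the one dose given (going by the name of the read-out) and lower numbers for less inhibition), gives < 2%; this is a limit of the assay, not a number.
Compound 2, `Cc1cc(C(=O)O)nn1-c1ccc(S(=O)(=O)NC(=S)NC2CCCCC2)cc1`, in this assay gives 1%.
Compound 3, `CCCNC(=S)NS(=O)(=O)c1ccc(-n2nc(C(=O)O)cc2C)cc1`, in this assay gives < 1%, again a limit of the assay.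

Compound 1 therefore stands only at a limit, as does compound 3 (the limit of < 2% in this assay, at which 1 of the 3 values shown sits, (the limit of < 1% in this assay, at which 1 of the 3 values shown sits)), while compound 2 sits at a number in the same low region. The three measured steps, a step that the limit leaves unreadable from compound 1 to compound 2, a step that the two limits leave unreadable from compound 1 to compound 3 and a number no higher from compound 2 to compound 3 (the limit leaves the size open), all change the group on the amide-type nitrogen, and none has a readable size. Compound 4, `Cc1cc(C)n(-c2ccc(S(=O)(=O)NC(=S)NCc3ccccc3)cc2)n1`, differs elsewhere: methyl in place of carboxy on an aromatic carbon. For the measured compounds named here, no measured step alters that position, so none bears directly on this change. Every measured compound sits near the floor of the read-out. Compound 4 is expected to stay there too, with an estimated step of a number at least 1 percentage points higher from compound 1 to compound 4 (that floor lies within the scatter) and an estimated value of 3%, from 0% to 15%, in this assay.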

Compound 4, a percentage reported as inhibition, in the whole organism at one dose (the size of the read-out at that dose, not a potency): 0%
Beside the measured number, compound 4's estimate is 3 percentage points above it, and the stated range covers the measured number.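

For the compounds shown here, the change from compound 1, whose value is only a limit of the assay, to compound 4 gives no step that can be read. The compounds shown leave open whether methyl in place of carboxy matters for any compound with clear inhibition in this assay.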